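Solubility notes: trifluoromethyl to methyl in the urea pair

The compounds below may be only part of what the source reports. "The series", "measured", "known", "first", "only" and "open" are said of these compounds alone.

Three compounds of this series share a core and have been run in a physicochemical assay for solubility, read by HPLC, with a stated time of 4 h, at pH 7; a higher number here means a more soluble compound, a lower number a less soluble compound. Compound 1 `C[C@]1(COc2ccc(NC(=O)Nc3ccc(C(F)(F)F)cc3)cc2)Cn2cc([N+](=O)[O-])nc2O1` returns only a limit, < 1 ug/mL. Compound 2 `C[C@]1(COc2ccc(N3CCN(S(=O)(=O)c4ccc(C(F)(F)F)cc4)CC3)cc2)Cn2cc([N+](=O)[O-])nc2O1` likewise returns a limit, < 1 ug/mL. Compound 3 `C[C@]1(COc2ccc(-n3cc(COc4ccc(OC(F)(F)F)cc4)nn3)cc2)Cn2cc([N+](=O)[O-])nc2O1` also returns a limit, < 1 ug/mL. Among the measured compounds shown here, compound 1 therefore stands at the limit of < 1 ug/mL in this assay, at which 3 of the 3 values shown sit, and no measured step separates any pair, so no size of change has been observed so far. Compound 4 `Cc1ccc(NC(=O)Nc2ccc(OC[C@@]3(C)Cn4cc([N+](=O)[O-])nc4O3)cc2)cc1` is not yet measured; it differs from compound 1 by methyl in place of trifluoromethyl on an aromatic carbon. The step that this estimate implies, an at least 2.0-fold higher number from compound 1 to compound 4 (0.30 log units; that floor lies within the scatter), is expected to be small, a modest rise at most. Compound 4 is estimated at 2 ug/mL, with a range from 0.5 ug/mL to 8 ug/mL, and a fair chance that this assay again reports only a limit.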

Compound 4, solubility: < 1 ug/mL
Compound 4: only a limit was reported; the forecaster's own chance of this, stated with the estimate: 40%; middle value at least 2.0-fold (0.30 log units) from the limit.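

Among the compounds shown here, compound 1 and compound 4 both return only a limit in this assay, so no step between them can be read. The compounds shown leave open whether methyl in place of trifluoromethyl changes the read-out at all, and how the compounds rank: the limit of < 1 ug/mL in this assay, at which 4 of the 4 values shown sit.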